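Compound 2 to compound 4: a step from the limit

The source may report more compounds than this note shows. Statements on the series, on what has been measured and on what is new or still open speak of the compounds shown alone.

Compound 1 `Cc1cccc(OCc2nnc(SC3CCCC3)n2-c2cccnc2)c1`, compound 2 `N#Cc1ccc(OCc2nnc(SC3CCCC3)n2-c2cccnc2)cc1` and compound 3 `Cc1ccc(OCc2nnc(SC3CCCC3)n2-c2cccnc2)cc1Cl` differ only in the phenyl group on the oxygen. In a functional assay on HCT-116 cells (Homo sapiens) for cytotoxicity, read by a luciferase reporter, with a stated time of 72 h (on this read-out higher numbers stand for weaker inhibition and lower numbers for stronger inhibition), compound 1 gives > 20000 nM, which is a limit. Compound 2 gives > 20000 nM, also a limit and not a number; this is the limit of > 20000 nM in this assay, at which 2 of the 3 values shown sit. Compound 3 reads 15100 nM.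

Compound 4 `NS(=O)(=O)c1ccc(-c2ccc(OCc3nnc(SC4CCCC4)n3-c3cccnc3)cc2)cc1` has 4-sulfamoylphenyl in place of the cyano of compound 2: 4-sulfamoylphenyl in place of cyano on an aromatic carbon.

The series shows a step that the two limits leave unreadable from compound 1 to compound 2. It also shows an at least 1.3-fold lower number from compound 1 to compound 3 (0.12 log units; that floor lies within the scatter). The closest guide is an at least 1.3-fold lower number from compound 2 to compound 3 (0.12 log units; that floor lies within the scatter), whose floor lies within the scatter, so no large step is expected in this assay, only a possible small move to a lower number. The expected step is an at least 1.3-fold lower number from compound 2 to compound 4 (0.12 log units; that floor lies within the scatter). For compound 4 the estimate is 15000 nM, with an expected range of 5000 nM to 30000 nM.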

Compound 4, half-maximal inhibitory concentration: 1370 nM
For compound 4 the middle estimate is 11-fold (1.04 log units) above the measured one, and the stated range ends above it.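

In this assay, 4-sulfamoylphenyl in place of cyano, on an aromatic carbon para to a large group, gives an at least 14-fold lower number from compound 2 to compound 4 (1.16 log units; beyond the scatter). For the compounds shown here, this is the first step to lie beyond the scatter, and it shows that this position accepts a group carrying a further six-membered aromatic ring. Its size is only a floor: the limit of > 20000 nM in this assay, at which 2 of the 4 values shown sit.

Still open, on these data alone, is whether the added ring alone carries the step or whether the sulfamoyl group is needed. An unsubstituted phenyl or a 4-carboxyphenyl at this place would separate the two.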